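Furan-3-yl in place of 1H-imidazol-4-yl on the shared core

The compounds below may be only part of what the source reports. "The series", "measured", "known", "first", "only" and "open" are said of these compounds alone.

In a functional assay on HCT-116 cells (Homo sapiens), read by sulforhodamine B assay, with a stated time of 5 days (on this read-out lower numbers stand for stronger inhibition of growth and higher numbers for weaker inhibition of growth), compound 1 `OC[C@H]1O[C@@H](n2cc(F)c3c(-c4nccs4)ncnc32)[C@H](O)[C@@H]1O` gives 1300 nM as a measured number. Compound 2 `OC[C@H]1O[C@@H](n2cc(F)c3c(-c4c[nH]cn4)ncnc32)[C@H](O)[C@@H]1O` gives > 10000 nM as a limit of the assay and not a number. Compound 2 stands only at the limit of > 10000 nM in this assay, at which 1 of the 2 values shown sits, and so has no number of its own.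

Compound 3 `OC[C@H]1O[C@@H](n2cc(F)c3c(-c4ccoc4)ncnc32)[C@H](O)[C@@H]1O` carries furan-3-yl in place of the 1H-imidazol-4-yl of compound 2, on the same aromatic carbon (furan-3-yl in place of 1H-imidazol-4-yl on an aromatic carbon). Among the compounds with values here, only one measured step bears on this change (an at least 7.6-fold higher number from compound 1 to compound 2 (0.88 log units; beyond the scatter)), and it lies beyond the scatter. That step brought in the same 1H-imidazol-4-yl that now leaves, though in exchange for a different group. A step in the opposite direction is therefore expected, of at least similar size, but the limit on compound 2 leaves its true size open. In this assay the estimated step is an at least 33-fold lower number from compound 2 to compound 3 (1.52 log units; beyond the scatter) towards stronger inhibition of growth. Compound 3 is expected at 300 nM with an estimated range of 40 nM to 2500 nM around it.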

Compound 3, concentration for 50% growth inhibition: 18 nM
The estimate for compound 3 lay 17-fold (1.22 log units) above the measured number; measured number below the stated range.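

At this aromatic carbon, the choice among five-membered aromatic rings sets the level of growth inhibition in this assay: furan-3-yl in place of 1,3-thiazol-2-yl gives a 72-fold lower number from compound 1 to compound 3 (1.86 log units; beyond the scatter), so the value of the thiazole no longer marks the upper end of what this position can give. Furan-3-yl in place of 1H-imidazol-4-yl gives an at least 550-fold lower number from compound 2 to compound 3 (2.74 log units; beyond the scatter), a change that keeps the count of 5 heavy atoms and the single hydrogen-bond acceptor but removes the hydrogen-bond donor, and furan-3-yl is the strongest of the three groups shown. The true size of that step stays open, and only its lower end can be read, because compound 2 carries a limit of the assay and not a number: the limit of > 10000 nM in this assay, at which 1 of the 3 values shown sits.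

The three compounds do not separate the loss of the hydrogen-bond donor from the other differences between the rings, since each change swaps a whole ring. Going by these compounds, how a six-membered ring such as phenyl, an amine or a longer alkyl chain on this carbon would stand against furan-3-yl remains open, as does whether the order of the groups holds on a core without the fluorine.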